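Benzyl for Cyclohexyl on an Aromatic Nitrogen: Lipophilicity

This account rests on a few compounds, and the source may have more. Where it says the series, first, only, none or still open, it means among the compounds named here.

The series begins with compound 1 `CCc1ccc(-c2cn3ccnc3c(-c3ccc4ncn(C5CCCCC5)c4c3)n2)cc1`, which in a physicochemical assay for lipophilicity, using the shake flask method, in phosphate buffer, measured as octanol-water partition, with a stated time of 85 min, at pH 7.4 (a lower number here means a more polar compound, a higher number a more lipophilic compound), gives 1.66. Compound 2 `CCc1ccc(-c2cn3ccnc3c(-c3ccc4ncn(Cc5ccccc5)c4c3)n2)cc1` keeps the same core and differs only by benzyl in place of cyclohexyl on an aromatic nitrogen; in this assay compound 2 gives 1.96. The step is a number 0.30 log units higher from compound 1 to compound 2 (within the scatter), so the two values cannot be told apart with confidence.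

Compound 3 `c1cn2cc(-c3ccc4c(c3)ncn4C3CCCCC3)nc(-c3ccc4ncn(C5CCCCC5)c4c3)c2n1` carries a different core; the difference between the core of compound 1 and the core of compound 3 is not broken down here. In this assay compound 3 gives 1.9, a value that sits close to compound 2 and within the scatter of compound 1 as well.

Compound 4 `c1ccc(Cn2cnc3ccc(-c4nc(-c5ccc6c(c5)ncn6C5CCCCC5)cn5ccnc45)cc32)cc1` is built from compound 3 by the same change that turned compound 1 into compound 2, namely (benzyl in place of cyclohexyl on an aromatic nitrogen). Since the earlier step of this kind was a number 0.30 log units higher from compound 1 to compound 2 (within the scatter), a shift of about the same size is expected here, and the step from compound 3 to compound 4 is estimated as a number 0.30 log units higher from compound 3 to compound 4 (within the scatter). On that basis compound 4 is expected to give about 2.2 in this assay. Among the compounds with values here, the expected range for compound 4 runs from 1.8 to 2.6, an interval that reflects both the single precedent and the ordinary scatter of this measurement.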

Compound 4, partition coefficient: 1.61
For compound 4 the middle estimate is 0.59 log units above the measured one; the whole stated range lies above it.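

In this assay, the exchange of cyclohexyl for benzyl on an aromatic nitrogen, carried onto the core of compound 3, gives a number 0.29 log units lower from compound 3 to compound 4 (within the scatter), whereas on the core of compound 1 it gave a number 0.30 log units higher from compound 1 to compound 2 (within the scatter), so the printed numbers carry opposite signs. Both steps lie within the scatter, so neither core shows a shift that can be told apart from repeat measurement, and the opposite signs do not establish that the change behaves differently on one core than on the other; nor do these two pairs show that a shift of any particular size carries from one core to the other. No measurement offered here accounts for the opposite signs of the two steps.

The compounds shown leave open whether this exchange would give a step beyond the scatter on any further core. They also leave open how the partition read-out would respond if a chain ending in an amine or a carboxylic acid stood on the same aromatic nitrogen in place of cyclohexyl or benzyl.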